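The source may hold more compounds than are shown below. What is called first, only, known or untested is meant among the compounds shown, and "the series" means these compounds.

Within the data shown here, compound 1 `O=C(c1ccc(-c2ccc3ncc(-c4ccc5cnccc5c4)n3c2)cc1)N1CCC(N2CCCCC2)CC1` gives 2.4 nM in an assay on Sf21 cells for inhibition of MAP kinase-interacting serine/threonine-protein kinase 1 (Homo sapiens), read by luminescence and ADP-Glo, with stated times of 10 min and 40 min (a lower number here means a stronger inhibitor, a higher number a weaker inhibitor), the lower of the two numbers so far; compound 2 `NC1CCN(C(=O)c2ccc(-c3cn4c(-c5ccc6cnccc6c5)cnc4cn3)cc2)CC1` gives 32.1 nM in this assay. Compound 3 `O=C(c1ccc(-c2ccc3ncc(-c4ccc5cnccc5c4)n3c2)cc1)N1CCOCC1` is not yet measured. It differs from compound 1 in one place: morpholin-4-yl in place of 4-(piperidin-1-yl)piperidin-1-yl on a carbonyl carbon. Among the measured compounds shown here, no measured pair shows this change, so only an expectation can be given. For compound 3 a weaker inhibition is expected, the step of a 6.3-fold higher number from compound 1 to compound 3 (0.80 log units; beyond the scatter) lying beyond the usual scatter. Compound 3 is thus estimated at 15 nM, with a range from 4 nM to 60 nM.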

Compound 3, half-maximal inhibitory concentration: 7 nM
The estimate for compound 3 lay 2.1-fold (0.33 log units) above the measured number; measured number inside the range.
By their numbers in this assay, from the lowest: compound 1; then compound 3; then compound 2.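

At this position on the carbonyl carbon, morpholin-4-yl in place of 4-(piperidin-1-yl)piperidin-1-yl costs only a modest amount in this assay, with a 2.9-fold higher number from compound 1 to compound 3 (0.46 log units; beyond the scatter). The larger group is therefore not needed for strong inhibition on this core, since compound 3 still gives 7 nM. Nothing available accounts for the size of this step.

As far as these compounds go, it remains open how a piperazin-1-yl or dimethylamino group would read on the same carbonyl carbon. From the compounds shown here alone, whether the step would carry over to the core of compound 2 also remains open.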